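Larger alkyl at the methyl position of compound 2

A few compounds are considered here, and "the series" means these few. Any claim that something is new, unique, unknown or untested is made for them only; others in the source may bear on it.

A series of three measured acids sharing one core was examined in an assay on CHO cells for displacement of a labelled ligand from prostaglandin D2 receptor 2 (Homo sapiens), read by scintillation counting; on this read-out lower numbers stand for stronger inhibition and higher numbers for weaker inhibition. Compound 1 `CS(=O)(=O)c1cccc(C#Cc2cc(Cl)ccc2OCC(=O)O)c1` gives 15 nM. Compound 2 `Cc1ccc(S(C)(=O)=O)cc1C#Cc1cc(Cl)ccc1OCC(=O)O` carries a methyl on an aromatic carbon where compound 1 carries hydrogen. In this assay compound 2 gives 5 nM; the step of a 3.0-fold lower number from compound 1 to compound 2 (0.48 log units; beyond the scatter). Compound 3 `CCN(CC)S(=O)(=O)c1ccc(C)c(C#Cc2cc(Cl)ccc2OCC(=O)O)c1`, with diethylamino in place of methyl on the sulfonyl sulfur, gives 3.4 nM, and the step of a 1.5-fold lower number from compound 2 to compound 3 (0.17 log units; within the scatter). Within this set compound 2 has the second highest number: it stands within the scatter of compound 3 and beyond the scatter of compound 1.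

The unmeasured compound 4 `CC(C)c1ccc(S(C)(=O)=O)cc1C#Cc1cc(Cl)ccc1OCC(=O)O` differs from compound 2 by isopropyl in place of methyl on an aromatic carbon. Among the compounds with values here, the only measured step that touches this aromatic carbon is the one from hydrogen to methyl, a 3.0-fold lower number from compound 1 to compound 2 (0.48 log units; beyond the scatter), which was modest and beyond the scatter; no measured step shows what happens when the methyl is enlarged further. The data therefore support only a cautious expectation: the number for compound 4 is estimated to stay close to that of compound 2, with a step of a 1.2-fold higher number from compound 2 to compound 4 (0.08 log units; within the scatter) expected to fall within the scatter. Compound 4 is thus estimated at 6 nM, with a range from 2 nM to 18 nM.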

Compound 4, inhibition constant: 4.6 nM
Compound 4: the middle estimate sits 1.3-fold (0.12 log units) above what was measured; measured number inside the range.
By their numbers in this assay, from the lowest: compounds 3, 4 and 2 (each within the scatter of the next); then compound 1.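

In this assay this aromatic carbon, ortho to a large group and para to a methylsulfonyl group, takes isopropyl as readily as methyl: the change gives a 1.1-fold lower number from compound 2 to compound 4 (0.04 log units; within the scatter) and so separates the two groups by no more than the usual scatter. Within the data shown here, the advantage over hydrogen also holds for the larger group, since a 3.3-fold lower number from compound 1 to compound 4 (0.51 log units; beyond the scatter) stands alongside a 3.0-fold lower number from compound 1 to compound 2 (0.48 log units; beyond the scatter) and both steps lie beyond the scatter, so across hydrogen, methyl and isopropyl the only step beyond the scatter at this position is the one away from hydrogen. No supporting evidence bears on why the position behaves this way.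

The compounds shown do not say how far this tolerance extends, as a tert-butyl group, a cyclohexyl ring or a longer chain such as n-butyl at this carbon would test the limit of size, while a methoxy group or an amine would test whether an alkyl group is needed at all. They also leave open whether isopropyl at this carbon would behave the same way with the diethylamino group of compound 3 on the sulfonyl sulfur.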